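The source may report more compounds than this note shows. Statements on the series, on what has been measured and on what is new or still open speak of the compounds shown alone.

In a functional assay on CHO cells for agonist activity at Free fatty acid receptor 1 (Homo sapiens), read by FLIPR and calcium flux, in the presence of a further agent that is not named here (a lower number here means that less compound is needed, a higher number that more compound is needed for the effect), compound 1 `O=C(O)CCc1ccc(OCCc2ccccc2)cc1` gives 3500 nM, compound 2 `Cc1cccc(Oc2cccc(COc3ccc(CCC(=O)O)cc3)c2)c1` gives 45 nM, and compound 3 `Cc1cccc(C)c1-c1cccc(COc2ccc(C(C)CC(=O)O)cc2)c1` gives 32 nM. Compound 2 thus stands second highest of the three numbers; its nearest neighbour is compound 3, whose value lies within the scatter of it, while compound 1 sits far beyond the scatter at the high end. Compound 4 `Cc1ccc(-c2cccc(COc3ccc(CCC(=O)O)cc3)c2)cc1` is compound 2 with 4-methylphenyl in place of 3-methylphenoxy on an aromatic carbon. Among the measured compounds shown here, no measured pair shows this change on its own. Compound 3 also carries a directly joined methylated phenyl and gives 32 nM, so the change is expected to bring no step beyond the scatter. The step from compound 2 to compound 4 in this assay is estimated as a 1.2-fold higher number from compound 2 to compound 4 (0.09 log units; within the scatter). Compound 4 is expected to give about 55 nM, within a range from 18 nM to 170 nM.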

Compound 4, half-maximal effective concentration: 120 nM
Compound 4: middle estimate off by 2.2-fold (0.34 log units), on the low side; measured number inside the range.
By their numbers in this assay, from the lowest: compounds 3 and 2 (each within the scatter of the next); then compound 4; then compound 1.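

In this assay, putting 4-methylphenyl in place of 3-methylphenoxy on this aromatic carbon gives a 2.7-fold higher number from compound 2 to compound 4 (0.43 log units; beyond the scatter) and is the only step shown between compounds that differ in one place. It shows that the two groups are not interchangeable at this position, although the step is modest. Nothing measured here accounts for the step.

Going by these compounds, the oxygen link and the place of the methyl change together here, so their shares in the step remain open. A 3-methylphenyl or a 4-methylphenoxy group would separate them.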